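Trimming the pentamethylphenyl ring of compound 1: expected cytotoxicity

This account rests on a few compounds, and the source may have more. Where it says the series, first, only, none or still open, it means among the compounds named here.

Compound 1 `Cc1oc(-c2c(C)c(C)c(C)c(C)c2C)nc1CN1CCC(C(=O)NCCCN2C[C@H](C)C[C@H](C)C2)CC1` was tested in an ADME assay on Huh7.5.1 cells (Homo sapiens) for cytotoxicity, read by ATP content, with a stated time of 48 h (a lower number here means that less compound is tolerated, a higher number that more compound is tolerated), where compound 1 gives 8180 nM. Two companions share the same core: compound 3 `Cc1cccc(Cl)c1-c1nc(CN2CCC(C(=O)NCCCN3CCC(C)(C)CC3)CC2)c(C)o1` gives 11700 nM, and compound 2 `Cc1ccccc1-c1nc(CN2CCC(C(=O)NCCCN3CCC(C)CC3)CC2)c(C)o1` gives 12300 nM. Going by the values given here, all three numbers sit within the usual scatter of one another, so no compound can be set apart on these results.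

Compound 4 `Cc1cc(C)cc(-c2nc(CN3CCC(C(=O)NCCCN4C[C@H](C)C[C@H](C)C4)CC3)c(C)o2)c1` is not yet measured. It differs from compound 1 by 3,5-dimethylphenyl in place of 2,3,4,5,6-pentamethylphenyl on an aromatic carbon.

Among the compounds with values here, with no measured pair showing what such a change does to this read-out, the step from compound 1 to compound 4 is expected to stay within the scatter, as a 1.2-fold higher number from compound 1 to compound 4 (0.09 log units; within the scatter) expresses. Compound 4 is therefore estimated at 10000 nM, with a range from 5000 nM to 22000 nM.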

Compound 4, half-maximal cytotoxic concentration: 4050 nM
Beside the measured number, compound 4's estimate is 2.5-fold (0.39 log units) above it; measured number below the stated range.
By their numbers in this assay, from the lowest: compound 4; then compounds 1, 3 and 2 (each within the scatter of the next).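

Swapping 2,3,4,5,6-pentamethylphenyl for 3,5-dimethylphenyl gives, in this assay, a 2.0-fold lower number from compound 1 to compound 4 (0.31 log units; beyond the scatter), a modest step. This first single-place comparison shows that the group at this position can change how much compound the cells tolerate, with the smaller aromatic group tolerated less in this pair. Nothing available explains why the number moves in this direction. The compounds shown leave open which of the methyl groups present only in compound 1 matter, and whether an unsubstituted phenyl or a pyridine ring here would raise or lower the number.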